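The source may report more compounds than this note shows. Statements on the series, on what has been measured and on what is new or still open speak of the compounds shown alone.

Working notes on the series. In a functional assay on MDA-MB-436 cells (Homo sapiens) for antiproliferative activity, read by MTT assay, with a stated time of 48 h (a lower number here means a stronger inhibitor, a higher number a weaker inhibitor), compound 1 (`C=CS(=O)(=O)N1CCN(c2nc(OCC3CCCCN3C)nc3sc(-c4ccc(C#N)cc4)cc23)CC1`) gives 4080 nM and compound 2 (`CCS(=O)(=O)N1CCN(c2ncnc3sc(-c4ccc(N5CCN(C)CC5)cc4)cc23)CC1`) gives 10600 nM. Compound 2 holds the higher of the two numbers, and its gap to compound 1 lies beyond the scatter. For the measured compounds named here, these two compounds differ in more than one place, so no single-place step is available as a guide. Compound 3 (`CN1CCN(c2ccc(-c3cc4c(N5CCN(C(=O)Nc6ccccc6)CC5)ncnc4s3)cc2)CC1`) has not yet been measured. The change from compound 2 is phenylcarbamoyl in place of ethylsulfonyl on an amine nitrogen in a ring. Without a measured precedent for this change, only a modest shift toward a lower number in this assay is expected, near the edge of the scatter. The expected step is a 2.1-fold lower number from compound 2 to compound 3 (0.33 log units; beyond the scatter). The estimate for compound 3 is 5000 nM, with an expected range of 1500 nM to 16000 nM.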

Compound 3, half-maximal inhibitory concentration: 7090 nM
For compound 3 the middle estimate is 1.4-fold (0.15 log units) below the measured one; the measured number falls inside the stated range.
By their numbers in this assay, from the lowest: compounds 1, 3 and 2 (each within the scatter of the next, the first and the last beyond it).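

this assay gives the first single-place reading at this position: phenylcarbamoyl in place of ethylsulfonyl on an amine nitrogen in a ring gives a 1.5-fold lower number from compound 2 to compound 3 (0.17 log units; within the scatter). The entering group adds a six-membered aromatic ring of carbon only and a hydrogen-bond donor, and replaces the sulfonyl with a carbonyl, yet the numbers of compound 2 and compound 3 lie within the scatter of each other, so this exchange leaves no resolved change in this read-out. Nothing at hand explains this result.

Still open, as far as these compounds go, is which part of the phenylcarbamoyl group matters, if any, since the ring and the amide hydrogen enter together. A benzoyl or methylcarbamoyl group on the same nitrogen would separate the two.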